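A few compounds are considered here, and "the series" means these few. Any claim that something is new, unique, unknown or untested is made for them only; others in the source may bear on it.

Compound 3 `CC(=O)Nc1ccc(Cc2noc(CCC(=O)Nc3ccc(F)cc3F)n2)cc1` gives 52.1% in a functional assay on the whole organism (strain C57BL/6) for inhibition, with Mus musculus as the target, read by paw edema, with stated times of 1 h and 4 h, at a dose of 100 mg/kg by the oral route (a higher number here means more inhibition at the dose given (going by the name of the read-out), a lower number less inhibition), and stands second highest of the three measured numbers. Compound 2 `COc1ccccc1NC(=O)CCc1nc(Cc2ccc(NC(C)=O)cc2)no1` gives 87.7% in this assay, while compound 1 `COc1cccc(NC(=O)CCc2nc(Cc3ccc(NC(C)=O)cc3)no2)c1` gives 35.6%. The steps of a number 16.5 percentage points higher from compound 1 to compound 3 (beyond the scatter) and a number 35.6 percentage points lower from compound 2 to compound 3 (beyond the scatter) show that the group on the amide-type nitrogen moves this read-out by modest to large amounts. Compound 4 `CC(=O)Nc1ccc(Cc2noc(CCC(=O)NCc3ccccc3)n2)cc1` differs from compound 3 in one place: benzyl in place of 2,4-difluorophenyl on an amide-type nitrogen. Within the data shown here, no measured step swaps an aryl group for a benzyl group, so none bears directly on this change, and any step in this assay beyond the scatter could go either way. Compound 4 is therefore expected to give about 45%, between 20% and 75%, meaning an expected step of a number 7.1 percentage points lower from compound 3 to compound 4 (within the scatter).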

Compound 4, a percentage reported as inhibition, in the whole organism at one dose (the size of the read-out at that dose, not a potency): 76.7%
Compound 4: middle estimate off by 31.7 percentage points, on the low side, and the stated range ends below it.
By their numbers in this assay, from the lowest: compound 1; then compound 3; then compound 4; then compound 2.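

Benzyl on the amide-type nitrogen keeps the read-out in this assay well up among the aryl groups, with a number 24.6 percentage points higher from compound 3 to compound 4 (beyond the scatter) and a number 41.1 percentage points higher from compound 1 to compound 4 (beyond the scatter) as the two upward steps. It still falls short of 2-methoxyphenyl, with a number 11 percentage points lower from compound 2 to compound 4 (beyond the scatter) as the step down, so aryl against benzyl alone does not set the order at this position. Nothing measured here accounts for these steps. As far as these compounds go, whether a 2-methoxybenzyl group would combine the two best results remains open, as does the effect of a longer chain such as phenethyl on the same nitrogen.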